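Cytotoxicity notes on the chlorobenzonitrile pyrazole series

A few compounds are considered here, and "the series" means these few. Any claim that something is new, unique, unknown or untested is made for them only; others in the source may bear on it.

The series shares one core, seen in compound 1 `C[C@@H](Cn1ccc(-c2ccc(C#N)c(Cl)c2)n1)NS(=O)(=O)c1cn(C)cn1` and compound 2 `C[C@@H](Cn1ccc(-c2ccc(C#N)c(Cl)c2)n1)Nc1ccccn1`. Readings come from an ADME assay on PC-3 cells (Homo sapiens) for cytotoxicity, read by CCK-8 assay, with a stated time of 6 days; on this read-out lower numbers stand for stronger inhibition and higher numbers for weaker inhibition. In this assay compound 1 gives > 30000 nM, which is a limit of the assay and not a number. Among the measured compounds shown here, for compound 2 this assay records "not determined" (no result reported), so no number is known for it; the only other value in the set is the one described by the limit of > 30000 nM in this assay, at which 1 of the 2 values shown sits, and compound 2 therefore stands without a measured position on the scale.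

Compound 3 `Cc1ccnc(N[C@@H](C)Cn2ccc(-c3ccc(C#N)c(Cl)c3)n2)n1` is still to be measured. It differs from compound 2 by 4-methylpyrimidin-2-yl in place of pyridin-2-yl on an amine nitrogen. For the measured compounds named here, no step between measured compounds exists in this set, so the size of the change in this assay cannot be taken from measured pairs. Given that the one reading in the set, from compound 1, is the limit described by the limit of > 30000 nM in this assay, at which 1 of the 2 values shown sits, the expectation is that compound 3 will also show weak inhibition, with a fair chance that only a limit is reported again. The estimate for compound 3 in this assay is 40000 nM, within 8000 nM to 200000 nM.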

Compound 3, half-maximal inhibitory concentration: > 30000 nM
Compound 3: a limit, no number (the forecaster's own chance of this, stated with the estimate: 75%); the middle value lies beyond the limit too.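

In this assay compound 3 gives > 30000 nM as a limit and not a number. No step can be read from compound 1 to compound 3, because both readings are limits: the limit of > 30000 nM in this assay, at which 2 of the 3 values shown sit.

The compounds shown leave open whether any change on the amine nitrogen gives a numerical reading in this assay at all.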